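Sulfanylmethyl for hydroxycarbamoyl on the chain of compound 1

This account rests on a few compounds, and the source may have more. Where it says the series, first, only, none or still open, it means among the compounds named here.

In a functional assay on HCT-116 cells (Homo sapiens) for antiproliferative activity, read by sulforhodamine B assay, with a stated time of 72 h (on this read-out lower numbers stand for stronger inhibition and higher numbers for weaker inhibition), compound 1 (`Cn1cc(-c2ccc(=O)n(CCOc3ccnc4cc(OCCCCC(=O)NO)ccc34)n2)cn1`) gives > 10000 nM, which is a limit of the assay and not a number. Compound 2 (`Cn1cc(-c2ccc(=O)n(CCOc3ccnc4cc(OCCCCCC(=O)Nc5ccccc5N)ccc34)n2)cn1`) gives 7000 nM. Compound 3 (`Cn1cc(-c2ccc(=O)n(CCOc3ccnc4cc(OCCCCCS)ccc34)n2)cn1`) carries sulfanylmethyl in place of hydroxycarbamoyl on a saturated chain carbon, four bonds along the chain from an oxygen on an aromatic ring. Among the compounds with values here, the only measured step at this place is an at least 1.4-fold lower number from compound 1 to compound 2 (0.15 log units; that floor lies within the scatter), so it offers weak guidance. No change beyond the scatter is expected in this assay, and the estimated step is an at least 1.1-fold lower number from compound 1 to compound 3 (0.04 log units; that floor lies within the scatter). Compound 3 is expected at 9000 nM, with an estimated range of 3000 nM to 27000 nM.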

Compound 3, half-maximal inhibitory concentration: > 10000 nM
Compound 3 ended at the assay's limit (the forecaster's own chance of this, stated with the estimate: 45%); middle value at least 1.1-fold (0.04 log units) away from the limit.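

In this assay compound 3 gives > 10000 nM, a limit of the assay and not a number, so the step between compound 1 and compound 3 cannot be read. Within the data shown here, the one readable step is an at least 1.4-fold higher number from compound 2 to compound 3 (0.15 log units; that floor lies within the scatter), so sulfanyl at this place does not bring the number down from that of the (2-aminophenyl)carbamoyl end. Most of the set now rests at the edge of the read-out: the limit of > 10000 nM in this assay, at which 2 of the 3 values shown sit.

From the compounds shown here alone, how compound 1 and compound 3 rank against each other stays open. Also open, going by these compounds, is whether a carboxylic acid or an amine at this chain end would give a number inside the read-out.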